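This account rests on a few compounds, and the source may have more. Where it says the series, first, only, none or still open, it means among the compounds named here.

Compound 1 `O=C(Nc1cccc(-n2cc(-c3ccncc3)c(-c3cc(O)cc(Cl)c3)n2)c1)Nc1ccc(Cl)c(C(F)(F)F)c1` is a urea carrying a phenol on its core. In a functional assay on BT-549 cells (Homo sapiens) for inhibition, read by sulforhodamine B assay, with a stated time of 48 h, tested at 1 uM (on this read-out higher numbers stand for a weaker effect at the one concentration tested and lower numbers for a stronger effect), compound 1 gives 90%. Compound 2 `O=C(Nc1cccc(-n2cc(-c3ccncc3)c(-c3cc(O)cc(Cl)c3)n2)c1)Nc1ccc(Cl)c(Cl)c1` differs from it only by chloro in place of trifluoromethyl on an aromatic carbon, and in this assay compound 2 gives 89%. The step of a number 1 percentage points lower from compound 1 to compound 2 (within the scatter) shows that the two numbers sit within the scatter of each other, so compound 1 stands level with compound 2 on the two values shown.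

Compound 3 `COc1cc(Cl)cc(-c2nn(-c3cccc(NC(=O)Nc4ccc(Cl)c(C(F)(F)F)c4)c3)cc2-c2ccncc2)c1` is the next compound. Its change from compound 1 is methyl in place of hydrogen on an oxygen on an aromatic ring. Within the data shown here, no measured step touches this oxygen; the one step available alters the far end of the urea and bears on it only by showing that the read-out stayed flat there. With nothing pointing otherwise, the expected step of no change at the digits printed from compound 1 to compound 3 (within the scatter) is none beyond the scatter, and for compound 3 the expected value is 90%, between 70% and 100%.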

Compound 3, a percentage reported as activity, at one concentration (the size of the read-out at that concentration, not a potency): 92%
Beside the measured number, compound 3's estimate is 2 percentage points below it; the measured number falls inside the stated range.
By their numbers in this assay, from the lowest: compounds 2, 1 and 3 (each within the scatter of the next).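

In this assay, putting methyl in place of hydrogen on this oxygen gives a number 2 percentage points higher from compound 1 to compound 3 (within the scatter), so compound 3 stands level with compound 1. The earlier pair spoke only to the far end of the urea, whereas this result shows that the read-out can also stay level when the hydroxy on the other side of the molecule becomes methoxy. Nothing available explains why this swap leaves the reading level.

Whether this position tolerates every replacement remains open, since only hydroxy and methoxy are shown here, and an amine or a carboxylic acid in place of the hydroxy, or a longer chain such as propyl on the oxygen, could read differently. A reading at one concentration also leaves open whether compound 1 and compound 3 would show a stronger or weaker effect than each other at any other concentration.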